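This account rests on a few compounds, and the source may have more. Where it says the series, first, only, none or still open, it means among the compounds named here.

Compound 1 `CCCOc1ccc(C[C@@H](Cc2ccccc2)C(=O)O)cc1CNC(=O)c1ccc(-c2ccncc2)cc1`: 34.1 ug/mL
Compound 2 `CCCOc1ccc(C[C@@H](Cc2ccccc2)C(=O)O)cc1CNC(=O)c1ccc(-c2ccc(F)cc2)cc1`: < 1 ug/mL

In a physicochemical assay for solubility, read by HPLC, in phosphate buffer, measured as thermodynamic solubility, with a stated time of 48 h, at pH 7.2 (on this read-out lower numbers stand for lower solubility and higher numbers for higher solubility), compound 1 gives 34.1 ug/mL. For compound 2 the assay reports only a limit, < 1 ug/mL. Compound 2 therefore stands at the limit of < 1 ug/mL in this assay, at which 1 of the 2 values shown sits. Compound 3 `CCCOc1ccc(C[C@@H](Cc2ccccc2)C(=O)O)cc1CNC(=O)c1ccc(-c2cccnc2)cc1` differs from compound 2 by pyridin-3-yl in place of 4-fluorophenyl on an aromatic carbon. Going by the values given here, the one measured step that bears on this change is an at least 34-fold lower number from compound 1 to compound 2 (1.53 log units; beyond the scatter), in which a pyridin-4-yl gave way to 4-fluorophenyl; the present change runs the other way, bringing in pyridin-3-yl. A rise in this assay beyond the scatter is therefore expected, estimated at an at least 25-fold higher number from compound 2 to compound 3 (1.39 log units; beyond the scatter). Compound 3 is expected to give 25 ug/mL, within a range of 5 ug/mL to 80 ug/mL.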

Compound 3, solubility: 69.5 ug/mL
The estimate for compound 3 lay 2.8-fold (0.44 log units) below the measured number, within the range that was stated.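

In this assay, the rise seen with pyridin-4-yl is not tied to that one ring: at this aromatic carbon, para to a large group, pyridin-3-yl in place of 4-fluorophenyl gives an at least 69-fold higher number from compound 2 to compound 3 (1.84 log units; beyond the scatter). On these data alone, the size of that step remains open-ended, as compound 2 sits at a limit of the assay: the limit of < 1 ug/mL in this assay, at which 1 of the 3 values shown sits. The site of the ring nitrogen also shows in the read-out, with a 2.0-fold higher number from compound 1 to compound 3 (0.31 log units; beyond the scatter). The compounds shown leave open how a pyridin-2-yl, a pyrimidin-5-yl or a phenyl carrying a dimethylamino group would read at this place.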